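Notes on 3-chlorophenyl versus 4-chlorophenyl in the series

The source may report more compounds than this note shows. Statements on the series, on what has been measured and on what is new or still open speak of the compounds shown alone.

Of the compounds shown here, two have numbers so far. In a functional assay on MCF7 cells (Homo sapiens) for cytotoxicity, read by ELISA, with a stated time of 4 days (on this read-out lower numbers stand for stronger inhibition and higher numbers for weaker inhibition), compound 1 (`Cc1ccsc1-c1cc(-c2ccco2)cc(-c2ccc(Cl)cc2)n1`) gives 890 nM. Compound 2 (`Cc1ccsc1-c1cc(-c2ccc(Cl)o2)cc(-c2cccc(Cl)c2)n1`) gives 18800 nM, the higher of the two numbers, and the gap to compound 1 lies beyond the scatter. These two compounds do not differ in one place only, so no single structural change has a measured size yet.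

The next compound to be measured is compound 3 (`Cc1ccsc1-c1cc(-c2ccc(Cl)o2)cc(-c2ccc(Cl)cc2)n1`). It carries 4-chlorophenyl in place of the 3-chlorophenyl of compound 2, on an aromatic carbon: 4-chlorophenyl in place of 3-chlorophenyl on an aromatic carbon. For the measured compounds named here, the only evidence on the entering group is compound 1, which also carries 4-chlorophenyl and gives 890 nM. Going by these compounds, how much of the gap belongs to this group is unknown, and compound 3 keeps the 5-chlorofuran-2-yl group of compound 2. Only part of the gap is therefore expected to close. In this assay the expected change is toward a lower number and beyond the scatter, estimated as a 6.3-fold lower number from compound 2 to compound 3 (0.80 log units; beyond the scatter). For compound 3 the estimated value is 3000 nM, with an expected range of 700 nM to 13000 nM.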

Compound 3, half-maximal inhibitory concentration: 15300 nM
Compound 3: the middle estimate sits 5.1-fold (0.71 log units) below what was measured, outside the stated range (above it).
By their numbers in this assay, from the lowest: compound 1; then compounds 3 and 2 (each within the scatter of the next).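

In this assay, 4-chlorophenyl in place of 3-chlorophenyl gives a 1.2-fold lower number from compound 2 to compound 3 (0.09 log units; within the scatter), so on this aromatic carbon next to the ring nitrogen, the two groups cannot be told apart while the 5-chlorofuran-2-yl group is present. The step that does register is chloro in place of hydrogen on an aromatic carbon, a 17-fold higher number from compound 1 to compound 3 (1.24 log units; beyond the scatter), which places the large difference between these two compounds, which differ in one place, at the 5-chlorofuran-2-yl group and not at the chlorophenyl group. No measurement is available that would account for either result.

For the compounds shown here, whether the two chlorophenyl groups also match when hydrogen stands in place of that chloro remains open, since both have been compared only with the 5-chlorofuran-2-yl group present, and the single step at that carbon cannot show whether the two chlorophenyl groups would stay matched on the core of compound 1. Also open, going by these compounds, is whether the higher number belongs to chloro in particular or would also come with a methyl, a methoxy or an amine on that carbon.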